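The compounds below may be only part of what the source reports. "The series", "measured", "known", "first", "only" and "open" are said of these compounds alone.

Compound 1 `CSc1ccc(CN[C@@H]2C[C@H]3C[C@@H]([C@H]2C)C3(C)C)s1` gives 25000 nM in an ADME assay on MDCK cells (Canis lupus familiaris) for cytotoxicity, read by microscopy, with a stated time of 48 h; on this read-out higher numbers stand for lower toxicity in this test and lower numbers for higher toxicity in this test. Compound 2 `C[C@H]1[C@H](NCc2cccs2)C[C@H]2C[C@@H]1C2(C)C` gives 25000 nM in this assay; the step of no change at the digits printed from compound 1 to compound 2 (within the scatter) belongs to hydrogen in place of methylsulfanyl on an aromatic carbon. On the numbers so far, compound 2 stands level with compound 1 at the digits shown, the two readings lying within the scatter of each other, so neither can be called the more or the less toxic of the pair.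

Compound 3 `C[C@H]1[C@H](NCc2ccc(-c3ccc(Br)s3)s2)C[C@H]2C[C@@H]1C2(C)C` differs from compound 2 by 5-bromothiophen-2-yl in place of hydrogen on an aromatic carbon. Within the data shown here, the only measured step, from compound 1 to compound 2, removes a small group rather than adding a ring and was flat, so it does not bear on this change; nothing measured speaks to adding a 5-bromothiophen-2-yl group. The expected step of a 2.0-fold lower number from compound 2 to compound 3 (0.30 log units; within the scatter) is therefore set as a modest move toward higher toxicity, with a wide range that also covers no change. Compound 3 is estimated at 12500 nM, expected to lie between 5000 nM and 25000 nM.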

Compound 3, minimum cytotoxic concentration: 780 nM
Estimate against measurement, compound 3: 16-fold (1.20 log units) above; measured number below the stated range.
By their numbers in this assay, from the lowest: compound 3; then compounds 1 and 2 (each within the scatter of the next).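

Working notes: the place next to the ring sulfur, two ring bonds from the ring atom that bears a large group, is not indifferent to every substituent. In this assay the exchange of hydrogen for 5-bromothiophen-2-yl gives a 32-fold lower number from compound 2 to compound 3 (1.51 log units; beyond the scatter) and the exchange of methylsulfanyl for the same group gives a 32-fold lower number from compound 1 to compound 3 (1.51 log units; beyond the scatter) while hydrogen and methylsulfanyl themselves read level, so the series now holds its first step beyond the scatter, and it runs toward higher toxicity in this test. Nothing on hand accounts for the size of this step.

The entering group carries both a further five-membered aromatic ring and a bromine, and the compounds shown do not separate these two parts: an unsubstituted thiophen-2-yl or a plain phenyl at this place would show whether the ring alone goes with the lower number, and a chlorine or methyl in place of the bromine would test the halogen. Also open, on these data alone, is whether a carboxylic acid or an amine on the added ring would leave the number down at the level of compound 3 or return it to the level of compound 2.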